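A few compounds are considered here, and "the series" means these few. Any claim that something is new, unique, unknown or untested is made for them only; others in the source may bear on it.

Measured so far:
compound 1 `CC1CCCCC1N(CCCCCCN1C[C@H](O)[C@@H](O)[C@H](O)[C@H]1CO)C(=O)OC(C)(C)C`: 240000 nM
compound 2 `CC(C)(C)C(=O)N(CCCCCCN1C[C@H](O)[C@@H](O)[C@H](O)[C@H]1CO)c1ccc(F)cc1F`: > 500000 nM

In an ADME assay on Huh-7 cells (Homo sapiens) for cytotoxicity, read by MTT assay (a lower number here means that less compound is tolerated, a higher number that more compound is tolerated), compound 1 gives 240000 nM. For compound 2 only a limit is known: in this assay compound 2 gives > 500000 nM, which is a limit of the assay, as noted in the limit of > 500000 nM in this assay, at which 1 of the 2 values shown sits. Among the compounds with values here, no step between measured compounds is available. Compound 3 `CC(C)(C)C(=O)N(CCCCCCN1C[C@H](O)[C@@H](O)[C@H](O)[C@H]1CO)C1CCCC1` carries cyclopentyl in place of 2,4-difluorophenyl on an amide-type nitrogen. Since compound 2 stands at a limit, the expected step from compound 2 to compound 3 is an at least 1.4-fold lower number from compound 2 to compound 3 (0.15 log units; that floor lies within the scatter), no more than the usual scatter, if anything slightly downward. Compound 3 is estimated at 350000 nM, between 150000 nM and 800000 nM, with a fair chance of another limit.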

Compound 3, half-maximal cytotoxic concentration: > 500000 nM
Compound 3 ended at the assay's limit; the forecaster's own chance of this, stated with the estimate: 45%; middle value at least 1.4-fold (0.15 log units) away from the limit.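

Within the data shown here, no step from compound 2 to compound 3 can be read in this assay, since both compounds stand at a limit of the assay: the limit of > 500000 nM in this assay, at which 2 of the 3 values shown sit. On these data alone, whether cyclopentyl and 2,4-difluorophenyl on the amide-type nitrogen differ in this assay remains open.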